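The compounds below may be only part of what the source reports. "The series", "measured", "known", "first", "only" and "open" are said of these compounds alone.

Going by the values given here, compound 2 `CNc1ncnc2c1c(-c1ccco1)cn2[C@@H]1O[C@H](CO)[C@@H](O)[C@H]1O` is the lower of the two numbers measured so far in a functional assay on CCRF-CEM cells (Homo sapiens), read by MTT assay, with a stated time of 72 h (a higher number here means a weaker inhibitor, a lower number a stronger inhibitor), where compound 2 gives 180 nM. Compound 1 `COc1ncnc2c1c(-c1cc3ccccc3o1)cn2[C@@H]1O[C@H](CO)[C@@H](O)[C@H]1O` sits well apart from it: in this assay compound 1 gives 5370 nM. Compound 3 `COc1ncnc2c1c(-c1ccco1)cn2[C@@H]1O[C@H](CO)[C@@H](O)[C@H]1O` has not yet been measured. It differs from compound 2 by one change (methoxy in place of methylamino on an aromatic carbon). Among the compounds with values here, no measured pair shows this change on its own, so the expected step of a 5.0-fold higher number from compound 2 to compound 3 (0.70 log units; beyond the scatter) is a guess, taken as a loss of potency because compound 1, which also carries a methoxy, gives 5370 nM. Compound 3 is expected to give about 900 nM, within 250 nM to 4000 nM.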

Compound 3, half-maximal inhibitory concentration: 20 nM
Compound 3: the middle estimate sits 45-fold (1.65 log units) above what was measured; the measured number lies below the stated range.
By their numbers in this assay, from the lowest: compound 3; then compound 2; then compound 1.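

Methoxy in place of methylamino on this aromatic carbon gives a 9.0-fold lower number from compound 2 to compound 3 (0.95 log units; beyond the scatter) in this assay and so, with furan-2-yl in place, the methylamino hydrogen-bond donor is not required for a low number. With methoxy held, furan-2-yl in place of 1-benzofuran-2-yl gives a 270-fold lower number from compound 1 to compound 3 (2.43 log units; beyond the scatter) and so the high number of compound 1 goes with 1-benzofuran-2-yl, not with methoxy. Nothing at hand explains either step. From the compounds shown here alone, whether ethoxy or an unsubstituted amine on this carbon would keep the number as low remains open, as does whether the methoxy gain would hold alongside 1-benzofuran-2-yl.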